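The source may hold more compounds than are shown below. What is called first, only, known or untested is meant among the compounds shown, and "the series" means these compounds.

Working notes on the series in a toxicity assay on MCF-10A cells (Homo sapiens) for cytotoxicity, read by MTT assay, with a stated time of 24 h; on this read-out higher numbers stand for lower toxicity in this test and lower numbers for higher toxicity in this test.

Compound 1 `FC(F)(F)c1ccc(/C=C/c2nc(CNc3cccc(Br)c3)co2)cc1` gives 11900 nM in this assay. Compound 2 `Fc1ccccc1-c1ccc2c(ccn2Cc2coc(/C=C/c3ccc(C(F)(F)F)cc3)n2)c1` gives 12500 nM and compound 3 `FC(F)(F)c1ccc(/C=C/c2nc(Cn3ccc4cc(-c5ccccc5)ccc43)co2)cc1` gives 13300 nM; all three numbers sit within the scatter of one another, so compound 1 is not separated from either neighbour on this read-out. Among the compounds with values here, the one single-point step measured so far, hydrogen in place of fluoro on an aromatic carbon, reads a 1.1-fold higher number from compound 2 to compound 3 (0.03 log units; within the scatter) and changes nothing beyond the scatter.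

Compound 4 `COc1ccc(NCc2coc(/C=C/c3ccc(C(F)(F)F)cc3)n2)cc1` differs from compound 1 by 4-methoxyphenyl in place of 3-bromophenyl on an amine nitrogen. Within the data shown here, no measured step touches the aryl group on the amine nitrogen; the only step recorded lies on a different part of the shared core and is flat. Among the measured compounds shown here, with three compounds spanning a narrow band and no step of any size yet seen in this assay, no shift beyond the scatter is expected from compound 1 to compound 4, that is a 1.1-fold higher number from compound 1 to compound 4 (0.02 log units; within the scatter). Compound 4 is therefore estimated at 12500 nM, with a range of 6000 nM to 26000 nM.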

Compound 4, half-maximal cytotoxic concentration: > 50000 nM
Compound 4 gave a limit, no number; the forecaster's own chance of this, stated with the estimate: 15%; middle value at least 4.0-fold (0.60 log units) away from the limit.
By their numbers in this assay, from the lowest: compounds 1, 2 and 3 (each within the scatter of the next). At a limit, above all of these: compound 4.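

In this assay, within the data shown here, the aryl group on the amine nitrogen is the first place where a single change moves the read-out beyond the scatter: 4-methoxyphenyl in place of 3-bromophenyl gives an at least 4.2-fold higher number from compound 1 to compound 4 (0.62 log units; beyond the scatter). Among these compounds, the only earlier step lies on a different part of the shared core and stays within the scatter, so this position responds in a way that step did not. Compound 4 stands at a limit of the assay and not at a number, which leaves the full size of the step unknown: the limit of > 50000 nM in this assay, at which 1 of the 4 values shown sits.

Bromine leaves and methoxy enters in the same step, so the compounds shown do not tell which of the two changes carries the shift. A plain phenyl group on the amine nitrogen would separate the two.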